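Aryl swap on the aromatic nitrogen: compound 3 to compound 4

A few compounds are considered here, and "the series" means these few. Any claim that something is new, unique, unknown or untested is made for them only; others in the source may bear on it.

Measured so far in a functional assay on A549 cells (Homo sapiens) for inhibition, read by MTT assay, with a stated time of 72 h; a lower number here means a stronger inhibitor, a higher number a weaker inhibitor
compound 1 `COc1cc2c(Oc3ccc(NC(=O)c4nn(-c5ccc(C)cc5C)cc(C)c4=O)cc3)ccnc2cc1OCCCCCCC(=O)NO` gives 1840 nM
compound 2 `COc1cc2c(Oc3ccc(NC(=O)c4nn(-c5ccc(F)c(Cl)c5)cc(C)c4=O)cc3)ccnc2cc1OCCCCCCC(=O)NO` gives 380 nM
compound 3 `COc1cc2c(Oc3ccc(NC(=O)c4nn(-c5cccc(C(F)(F)F)c5)cc(C)c4=O)cc3)ccnc2cc1OCCCCCCC(=O)NO` gives 780 nM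

Compound 3 holds the second highest of the three numbers, with compound 2 nearest and compound 1 furthest. The next change leads to compound 4 `COc1cc2c(Oc3ccc(NC(=O)c4nn(-c5ccc(C)cc5)cc(C)c4=O)cc3)ccnc2cc1OCCCCCCC(=O)NO` and is 4-methylphenyl in place of 3-(trifluoromethyl)phenyl on an aromatic nitrogen on the shared core. Within the data shown here, no measured pair isolates this swap. Among the measured compounds shown here, of the measured aryl groups, the one in compound 1 looks closest to 4-methylphenyl. Read in reverse, a 2.4-fold lower number from compound 1 to compound 3 (0.37 log units; beyond the scatter) points to a higher number on leaving 3-(trifluoromethyl)phenyl. Alongside it, a 4.8-fold lower number from compound 1 to compound 2 (0.69 log units; beyond the scatter) and a 2.1-fold higher number from compound 2 to compound 3 (0.31 log units; beyond the scatter) show that all three measured aryl swaps are modest. Expected in this assay is a small move to a higher number, estimated as a 1.5-fold higher number from compound 3 to compound 4 (0.19 log units; within the scatter) for now. For compound 4 the estimated value is 1200 nM with an expected range of 550 nM to 2400 nM on present data.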

Compound 4, half-maximal inhibitory concentration: 160 nM
For compound 4 the middle estimate is 7.5-fold (0.88 log units) above the measured one, outside the stated range (below it).
By their numbers in this assay, from the lowest: compound 4; then compound 2; then compound 3; then compound 1.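

In this assay, 4-methylphenyl on the aromatic nitrogen gives the lowest number of the four aryl groups, with a 4.9-fold lower number from compound 3 to compound 4 (0.69 log units; beyond the scatter) and a 2.4-fold lower number from compound 2 to compound 4 (0.38 log units; beyond the scatter). Compound 4 carries no halogen or trifluoromethyl, so neither is required for a low number among these compounds. The largest step in the set comes from one small edit, hydrogen in place of methyl on an aromatic carbon, with a 12-fold lower number from compound 1 to compound 4 (1.06 log units; beyond the scatter), so this aryl group responds more strongly to that single methyl than to any other swap shown.

Going by these compounds, whether unsubstituted phenyl, 4-ethylphenyl or 4-methoxyphenyl would hold or lower the number remains open. No supporting measurement is available to explain these differences.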